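Working notes: amine substituents in a small series

The source may hold more compounds than are shown below. What is called first, only, known or untested is meant among the compounds shown, and "the series" means these compounds.

Compound 1 `COc1ccc(CNCc2c(OC)cc(Oc3cccc(Nc4ccccc4)c3)cc2OC)cc1`: 1890 nM
Compound 2 `COc1cc(Oc2cccc(Nc3ccccc3)c2)cc(OC)c1CNCc1ccccc1`: 3340 nM
Compound 3 `COc1cc(Oc2cccc(Nc3ccccc3)c2)cc(OC)c1CN[C@H](C)c1ccccc1`: 5120 nM

In a functional assay on HT-29 cells (Homo sapiens) for inhibition, read by MTT assay, with a stated time of 72 h (on this read-out lower numbers stand for stronger inhibition and higher numbers for weaker inhibition), compound 3 gives 5120 nM, a value not separated from that of compound 2. Within the data shown here, the one measured step beyond the scatter that reaches compound 3 is a 2.7-fold higher number from compound 1 to compound 3 (0.43 log units; beyond the scatter).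

Compound 4 `COc1cc(Oc2cccc(Nc3ccccc3)c2)cc(OC)c1CNC(C)C` has isopropyl in place of 1-phenylethyl on an amine nitrogen.

Among the measured compounds shown here, three measured steps bear on this change, all on the same substituent or its aromatic ring. The step of a 1.5-fold higher number from compound 2 to compound 3 (0.19 log units; within the scatter) concerns the added methyl alone and stays within the scatter. The step of a 1.8-fold higher number from compound 1 to compound 2 (0.25 log units; within the scatter) concerns the methoxy alone and also stays within the scatter. Only the combined change, already given for compound 1 and compound 3, is modest in size. For the measured compounds named here, no measured compound lacks the aromatic ring on this substituent, so the size of the step on its removal is not covered by the data, and the range has to stay wide. No step beyond the scatter is expected, and the estimated change is a 1.2-fold higher number from compound 3 to compound 4 (0.07 log units; within the scatter). For compound 4 the expected value in this assay is 6000 nM, with an estimated range of 2500 nM to 15000 nM.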

Compound 4, half-maximal inhibitory concentration: > 20000 nM
Compound 4 was reported as a limit; the forecaster's own chance of this, stated with the estimate: 10%; middle value at least 3.3-fold (0.52 log units) away from the limit.
By their numbers in this assay, from the lowest: compounds 1, 2 and 3 (each within the scatter of the next, the first and the last beyond it). At a limit, above all of these: compound 4.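

In this assay compound 4 gives > 20000 nM, a limit of the assay and not a number. Isopropyl on the amine nitrogen brings the first large loss in the series, seen against all three substituents that carry an aromatic ring: an at least 3.9-fold higher number from compound 3 to compound 4 (0.59 log units; beyond the scatter), an at least 5.9-fold higher number from compound 2 to compound 4 (0.77 log units; beyond the scatter), and an at least 10-fold higher number from compound 1 to compound 4 (1.02 log units; beyond the scatter). Among these compounds, the earlier steps among compound 1, compound 2 and compound 3 all kept that ring on the substituent and stayed within the scatter or modest in size, so in these four compounds activity in this assay is measurable only with the ring present, and the sole compound without it, compound 4, sits at the limit.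

The change removes the six-membered aromatic ring and also shortens the substituent, and the compounds shown do not separate these two differences: a cyclohexylmethyl group or a longer alkyl chain such as n-hexyl on the same nitrogen would be needed to tell them apart. As far as these compounds go, how far the true value of compound 4 lies beyond its limit also stays open, so the real size of all three steps remains unknown.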